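A few compounds are considered here, and "the series" means these few. Any claim that something is new, unique, unknown or untested is made for them only; others in the source may bear on it.

Working notes on the series. The shared core appears in compound 1 `N#CC1=C(N)Oc2c(c3nc4ccccc4nc3c3ccccc23)C12C(=O)N(Cc1cnnn1-c1ccc(F)cc1)c1ccccc12` and compound 2 `N#CC1=C(N)Oc2c(c3nc4ccccc4nc3c3ccccc23)C12C(=O)N(Cc1cnnn1-c1cccc(S(N)(=O)=O)c1)c1ccccc12`, which differ only at the aryl group on the aromatic nitrogen. In an ADME assay on L02 cells (Homo sapiens) for antiproliferative activity, read by MTT assay, with a stated time of 48 h (a lower number here means a stronger inhibitor, a higher number a weaker inhibitor), compound 1 gives only a limit, > 50000 nM. In this assay compound 2 likewise gives only a limit, > 50000 nM. Compound 2 thus stands at the limit, and the step that the two limits leave unreadable from compound 1 to compound 2 cannot be read in size or direction from the two values. Among the compounds with values here, the only evidence available is the limit of > 50000 nM in this assay, at which 2 of the 2 values shown sit, which carries no readable step at all.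

Compound 3 `Cc1ccc(C)c(-n2nncc2CN2C(=O)C3(C(C#N)=C(N)Oc4c3c3nc5ccccc5nc3c3ccccc43)c3ccccc32)c1` is the next member. It differs from compound 2 in one place: 2,5-dimethylphenyl in place of 3-sulfamoylphenyl on an aromatic nitrogen. Within the data shown here, the sole measured step that bears on a change at this aromatic nitrogen is the one from compound 1 to compound 2, and that step is unreadable, so no measured step supports an expectation of any particular size or direction in this assay for compound 3. Compound 3 is therefore expected in this assay to come out at an estimate of 50000 nM, with a range from 20000 nM to 100000 nM, and quite possibly as a limit once more. The step this estimate means, a number no higher from compound 2 to compound 3 (the limit leaves the size open), is expected to stay within the scatter.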

Compound 3, half-maximal inhibitory concentration: > 50000 nM
Compound 3 gave a limit, no number; the forecaster's own chance of this, stated with the estimate: 85%; the middle value lies on the limit itself.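

Compound 3 gives only a limit, so no new step can be read, and the steps among compound 1, compound 2 and compound 3 in this assay remain unreadable, with all values at one limit: the limit of > 50000 nM in this assay, at which 3 of the 3 values shown sit. The compounds shown leave open whether any aryl group on the aromatic nitrogen would give a number rather than a limit in this assay.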